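Methoxycarbonyl for Methyl on the Aryl Ring of Compound 3

A few compounds are considered here, and "the series" means these few. Any claim that something is new, unique, unknown or untested is made for them only; others in the source may bear on it.

Compound 1, `O=C1C=CC(OCC(F)(F)F)N1c1cc(Cl)cc(Cl)c1`: 2430 nM
Compound 2, `CC(C)NC1CC(=O)N(c2ccc(F)c(Cl)c2)C1OCC(F)(F)F`: > 100000 nM
Compound 3, `Cc1ccc(N2C(=O)C=CC2OCC(F)(F)F)cc1`: 15800 nM

In a functional assay on MDA-MB-231 cells (Homo sapiens) for inhibition (on this read-out lower numbers stand for stronger inhibition and higher numbers for weaker inhibition), compound 1 gives 2430 nM and compound 3 gives 15800 nM. For compound 2 the read-out is only a limit, > 100000 nM, not a number; this is the limit of > 100000 nM in this assay, at which 1 of the 3 values shown sits. Of the two numbers compound 3 stands highest, with compound 1 the nearer, and that gap lies beyond the usual scatter.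

Compound 4, `COC(=O)c1ccc(N2C(=O)C=CC2OCC(F)(F)F)cc1`, has not been measured in this assay. It differs from compound 3 by methoxycarbonyl in place of methyl on an aromatic carbon. Going by the values given here, no measured pair shows this change, so its effect is unknown. For compound 4 a step of a 1.8-fold lower number from compound 3 to compound 4 (0.24 log units; within the scatter) is expected, toward a lower number but of uncertain size. Compound 4 is estimated at 9000 nM, between 2500 nM and 40000 nM.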

Compound 4, half-maximal inhibitory concentration: 12100 nM
Estimate against measurement, compound 4: 1.3-fold (0.13 log units) below; the measured number falls inside the stated range.
By their numbers in this assay, from the lowest: compound 1; then compounds 4 and 3 (each within the scatter of the next). At a limit, above all of these: compound 2.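

In this assay, methoxycarbonyl in place of methyl gives a 1.3-fold lower number from compound 3 to compound 4 (0.12 log units; within the scatter). On the aromatic carbon para to a large group, the change to a group of 4 heavy atoms with 2 hydrogen-bond acceptors therefore leaves the number within the scatter of that for methyl. Nothing measured here accounts for this step.

From the compounds shown here alone, whether a carboxylic acid or an amine on this same carbon would give a step beyond the scatter stays open. So does whether a longer ester, such as ethoxycarbonyl, would read the same.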